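Glycine-to-alanine side-chain change in the chloropurine amide series

The compounds below may be only part of what the source reports. "The series", "measured", "known", "first", "only" and "open" are said of these compounds alone.

Compound 1 `O=C(O)CNC(=O)CN(c1nc(Cl)nc2[nH]cnc12)C1CC1` gives 38.9% in a functional assay on the whole organism (Tail, strain ICR) with Mus musculus as the target, in the tail flick test, with a stated time of 60 min, at a dose of 25 umol/kg by the oral route; a higher number here means a stronger effect of the compound at the dose given, a lower number a weaker effect. Compound 2 `NC(=O)CC[C@H](NC(=O)CN(c1nc(Cl)nc2[nH]cnc12)C1CC1)C(=O)O` gives 38.4% in this assay and holds the lower of the two numbers, with compound 1 nearest and within the scatter. For the measured compounds named here, the one step seen so far, a number 0.5 percentage points lower from compound 1 to compound 2 (within the scatter), thus left the read-out unchanged. Compound 3 `C[C@H](NC(=O)CN(c1nc(Cl)nc2[nH]cnc12)C1CC1)C(=O)O` is not yet measured; it differs from compound 2 by hydrogen in place of carbamoylmethyl on a saturated chain carbon, two bonds along the chain from an amide-type nitrogen and a carbonyl carbon. Since adding a side chain at this carbon changed nothing, removing most of it is expected to change nothing either, so a number 0.4 percentage points lower from compound 2 to compound 3 (within the scatter) is expected. Compound 3 is estimated at 38%, within 25% to 51%.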

Compound 3, a percentage reported as activity, at one dose (the size of the read-out at that dose, not a potency): 44.6%
Beside the measured number, compound 3's estimate is 6.6 percentage points below it; measured number inside the range.
By their numbers in this assay, from the lowest: compounds 2, 1 and 3 (each within the scatter of the next).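

Replacing carbamoylmethyl with hydrogen on this saturated chain carbon stays within the scatter in this assay (a number 6.2 percentage points higher from compound 2 to compound 3 (within the scatter)), and so does methyl in place of hydrogen on the same carbon (a number 5.7 percentage points higher from compound 1 to compound 3 (within the scatter)). Across hydrogen, methyl and 2-carbamoylethyl, the read-out at this single dose therefore does not tell the three side chains apart.

As far as these compounds go, whether a basic amine, a longer carbon chain or a phenyl ring at this carbon would give a number beyond the scatter remains open. No evidence on the reason for these numbers is available.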